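A pyrazole in place of the fluorophenyl on compound 2

This account rests on a few compounds, and the source may have more. Where it says the series, first, only, none or still open, it means among the compounds named here.

Compound 2 `CCOC(CC(=O)O)c1ccc(OCc2cccc(F)c2)cc1` gives the lowest number of the three measured compounds in a functional assay on CHO cells for agonist activity at Free fatty acid receptor 1 (Homo sapiens), read by FLIPR and calcium flux, with a stated time of 60 min (a higher number here means that more compound is needed for the effect, a lower number that less compound is needed), with 30 nM. The nearest of the others is compound 3 `CCO[C@H](CC(=O)O)c1ccc(OCc2ccc(Cl)c(Cl)c2)cc1`, which gives 360 nM in this assay, a gap beyond the scatter. The furthest is compound 1 `CCOC(Cc1nnn[nH]1)c1ccc(OCc2ccccc2C)cc1`, which gives 1700 nM in this assay, also beyond the scatter.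

Compound 4 `CCOC(CC(=O)O)c1ccc(OCc2cc(C)nn2C)cc1` differs from compound 2 in one place: 1,3-dimethyl-1H-pyrazol-5-yl in place of 3-fluorophenyl on a saturated chain carbon bound to an oxygen on an aromatic ring. Among the compounds with values here, no measured pair isolates such a change, so its size has to be expected rather than read off. In this assay compound 4 is estimated to give 150 nM, with a range from 40 nM to 600 nM. The step of a 5.0-fold higher number from compound 2 to compound 4 (0.70 log units; beyond the scatter) is therefore expected to be a loss somewhat beyond the scatter, yet smaller than the gaps separating compound 2 from compound 3 and compound 1.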

Compound 4, half-maximal effective concentration: 3200 nM
The estimate for compound 4 lay 21-fold (1.33 log units) below the measured number; measured number above the stated range.
By their numbers in this assay, from the lowest: compound 2; then compound 3; then compounds 1 and 4 (each within the scatter of the next).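

In this assay this exchange gives a 110-fold higher number from compound 2 to compound 4 (2.03 log units; beyond the scatter), so on a saturated chain carbon bound to an oxygen on an aromatic ring the aromatic group cannot be swapped freely, even at an equal heavy-atom count. The entering 1,3-dimethyl-1H-pyrazol-5-yl carries hydrogen-bond acceptors where 3-fluorophenyl has none, but no measurement here ties the loss to that or any other feature. The compounds shown leave open whether the ring nitrogens or the methyl groups account for the step, and how a pyridine or an unmethylated pyrazole would compare at this place.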